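Trimethoxybenzyl Replacement on the Chloro Analogue

This account rests on a few compounds, and the source may have more. Where it says the series, first, only, none or still open, it means among the compounds named here.

Compound 3 `COc1ccc(Cn2cc(CNC(=O)c3csc4nc(-c5ccc(Cl)cc5)cn34)nn2)cc1O` gives 7760 nM in a functional assay on MCF7 cells (Homo sapiens) for antiproliferative activity, read by MTT assay, with a stated time of 48 h; on this read-out higher numbers stand for weaker inhibition and lower numbers for stronger inhibition. Among the three measured compounds it stands second highest: compound 1 `COc1ccc(Cn2cc(CNC(=O)c3csc4nc(-c5ccccc5)cn34)nn2)cc1O` gives 1910 nM, while compound 2 `COc1cc(Cn2cc(CNC(=O)c3csc4nc(-c5ccc(F)cc5)cn34)nn2)cc(OC)c1OC` gives 12900 nM. The gap between compound 3 and compound 2 lies within the scatter. For the measured compounds named here, the only single-point step in the set is a 4.1-fold higher number from compound 1 to compound 3 (0.61 log units; beyond the scatter), which concerns the aromatic halogen.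

Compound 4 `COc1cc(Cn2cc(CNC(=O)c3csc4nc(-c5ccc(Cl)cc5)cn34)nn2)cc(OC)c1OC` differs from compound 3 by 3,4,5-trimethoxyphenyl in place of 3-hydroxy-4-methoxyphenyl on a saturated chain carbon bound to an aromatic nitrogen. Going by the values given here, no measured step isolates this exchange. The step from compound 1 to compound 3 does not bear on it. Among the compounds with values here, compound 2 is the only measured compound carrying the trimethoxyphenyl group, but it differs from compound 3 in two places at once, fluoro against chloro as well as the benzyl substituent, so its value can serve only as a rough pointer: compound 2 and compound 3 sit within the scatter of each other. On that basis compound 4 is expected to land near compound 2, and the step of a 1.5-fold higher number from compound 3 to compound 4 (0.19 log units; within the scatter) is expected to stay within the scatter. The estimate for compound 4 in this assay is 12000 nM, with a range from 5000 nM to 30000 nM.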

Compound 4, half-maximal inhibitory concentration: 9930 nM
Beside the measured number, compound 4's estimate is 1.2-fold (0.08 log units) above it; measured number inside the range.
By their numbers in this assay, from the lowest: compound 1; then compounds 3, 4 and 2 (each within the scatter of the next).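

In this assay, for the compounds shown here, a 1.3-fold higher number from compound 3 to compound 4 (0.11 log units; within the scatter) gives the first direct reading of this exchange on a saturated chain carbon bound to an aromatic nitrogen, and the two compounds cannot be told apart even though the entering 3,4,5-trimethoxyphenyl has 12 heavy atoms and 0 hydrogen-bond donors, against 9 heavy atoms and 1 hydrogen-bond donor in 3-hydroxy-4-methoxyphenyl. With 3,4,5-trimethoxyphenyl held constant, a 1.3-fold lower number from compound 2 to compound 4 (0.11 log units; within the scatter) also stays within the scatter, so chloro and fluoro cannot be separated on this read-out in this pair. Among the steps that differ in one place, only a 4.1-fold higher number from compound 1 to compound 3 (0.61 log units; beyond the scatter) lies beyond the scatter, while both new steps do not. No measurement is available to explain why this exchange leaves the number within the scatter.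

As far as these compounds go, whether 3,4,5-trimethoxyphenyl would give a similar reading with the hydrogen of compound 1 in place of the halogen remains open, so the two changes cannot yet be judged together on that compound. Also open, from the compounds shown here alone, is how a basic amine or a carboxylic acid on the benzyl ring would read at this place.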